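Replacing the dimethylaminophenyl group in a vinyl sulfone series

A few compounds are considered here, and "the series" means these few. Any claim that something is new, unique, unknown or untested is made for them only; others in the source may bear on it.

Three members of the shared core have been run through a functional assay on DU-145 cells (Homo sapiens) for inhibition, read by trypan blue exclusion, with a stated time of 96 h; on this read-out higher numbers stand for weaker inhibition of growth and lower numbers for stronger inhibition of growth. Compound 1 `CCOc1ccc(/C=C(\C(=O)c2ccc(Cl)cc2)S(=O)(=O)Cc2ccc(C)cc2)cc1OC` gives 10000 nM. Compound 2 `Cc1ccc(CS(=O)(=O)/C(=C/c2cccc(Cl)c2Cl)C(=O)c2ccc(Cl)cc2)cc1` gives 1000 nM, and the move from compound 1 to compound 2 is a 10-fold lower number from compound 1 to compound 2 (1.00 log units; beyond the scatter). Compound 3 `Cc1ccc(CS(=O)(=O)/C(=C/c2ccc(N(C)C)cc2)C(=O)c2ccc(Cl)cc2)cc1` gives 50000 nM, the highest of the three numbers: the step from compound 1 to compound 3 is a 5.0-fold higher number from compound 1 to compound 3 (0.70 log units; beyond the scatter), and the step from compound 2 to compound 3 is a 50-fold higher number from compound 2 to compound 3 (1.70 log units; beyond the scatter).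

Compound 4 `Cc1ccc(CS(=O)(=O)/C(=C/c2ccc(C)s2)C(=O)c2ccc(Cl)cc2)cc1` is the next member, and it differs from compound 3 in one place: 5-methylthiophen-2-yl in place of 4-(dimethylamino)phenyl on a double-bonded chain carbon bound to a double-bonded chain carbon. The two steps that reach compound 3 both bear on this change, since each removed the 4-(dimethylamino)phenyl group in the opposite direction and each moved the number well beyond the scatter. Compound 4 is therefore expected to give a lower number than compound 3, a step of a 13-fold lower number from compound 3 to compound 4 (1.10 log units; beyond the scatter), with the size uncertain because no thiophene has been measured here. Compound 4 is estimated at 4000 nM, within a range from 800 nM to 25000 nM.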

Compound 4, concentration for 50% growth inhibition: 25000 nM
Compound 4: middle estimate off by 6.3-fold (0.80 log units), on the low side; the measured number falls inside the stated range.
By their numbers in this assay, from the lowest: compound 2; then compound 1; then compounds 4 and 3 (each within the scatter of the next).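

In this assay, 5-methylthiophen-2-yl in place of 4-(dimethylamino)phenyl gives no change that can be told from the scatter (a 2.0-fold lower number from compound 3 to compound 4 (0.30 log units; within the scatter)), so compound 4 does not separate these two groups at this place. The thiophene does not reach the level set by the 2,3-dichlorophenyl group (a 25-fold higher number from compound 2 to compound 4 (1.40 log units; beyond the scatter)), and it also stands apart from the 4-ethoxy-3-methoxyphenyl group (a 2.5-fold higher number from compound 1 to compound 4 (0.40 log units; beyond the scatter)), though by a modest step. Nothing on hand accounts for these differences.

The compounds shown leave open whether both chlorine atoms of compound 2 are needed, which a 3-chlorophenyl or 2-chlorophenyl group at this place would test. They also leave open whether an unsubstituted thiophene or a 5-chlorothiophen-2-yl group would behave like compound 4.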